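Trimming the formyl group: expectations for compound 3

The source may report more compounds than this note shows. Statements on the series, on what has been measured and on what is new or still open speak of the compounds shown alone.

Two compounds have been measured in a functional assay on PC-3 cells (Homo sapiens) for antiproliferative activity, read by MTT assay, with a stated time of 48 h; a lower number here means a stronger inhibitor, a higher number a weaker inhibitor:
Compound 1 `COc1cc(/C=C/C(C)=O)ccc1OCc1cn(-c2ccccc2CO)nn1` gives 50300 nM.
Compound 2 `COc1cc(/C=C/C(C)=O)ccc1OCc1cn(-c2ccc(C=O)cc2)nn1` gives 80700 nM.

Both numbers are high, and the step of a 1.6-fold higher number from compound 1 to compound 2 (0.21 log units; within the scatter) is within the scatter, so compound 2 cannot be told apart from compound 1 on these data. Compound 3 `COc1cc(/C=C/C(C)=O)ccc1OCc1cn(-c2ccccc2)nn1` differs from compound 2 by hydrogen in place of formyl on an aromatic carbon. Within the data shown here, no measured step removes a formyl group: the only step on record, a 1.6-fold higher number from compound 1 to compound 2 (0.21 log units; within the scatter), swaps one substituent for another at a different place on the same phenyl and stays within the scatter. That single step gives no reason to expect a move beyond the scatter in this assay in either direction. Compound 3 is therefore estimated to give a number close to that of compound 2, 65000 nM, with a range from 25000 nM to 170000 nM, the expected step being a 1.2-fold lower number from compound 2 to compound 3 (0.09 log units; within the scatter).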

Compound 3, half-maximal inhibitory concentration: 78600 nM
Compound 3: the middle estimate sits 1.2-fold (0.08 log units) below what was measured; the measured number falls inside the stated range.
By their numbers in this assay, from the lowest: compounds 1, 3 and 2 (each within the scatter of the next).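

Removing the formyl group from the 4-formylphenyl of compound 2 leaves the number in this assay where it stood, with a 1.0-fold lower number from compound 2 to compound 3 (0.01 log units; within the scatter), so on these data the 4-formylphenyl and plain phenyl cannot be told apart. Among these compounds, the plain phenyl also gives the first direct comparison with the hydroxymethyl compound, with a 1.6-fold higher number from compound 1 to compound 3 (0.19 log units; within the scatter), so neither formyl nor hydroxymethyl can be told apart from hydrogen on this phenyl, even though the two groups sit at different places. Nothing available explains why these three numbers stay so close.

The compounds shown leave open whether an amine or a carboxylic acid on the aromatic carbon that carries the formyl group in compound 2 would move the number beyond the scatter. They also leave open whether a change elsewhere in the shared core would do more than these changes on the phenyl.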